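This account rests on a few compounds, and the source may have more. Where it says the series, first, only, none or still open, it means among the compounds named here.

Measured compounds:
Compound 1 `CCOC(=O)c1oc2cc(OC)cc(OC)c2c1C`: in a functional assay on NSCLC-N6 cells (Homo sapiens) for cytotoxicity, read by MTT assay (on this read-out lower numbers stand for stronger inhibition and higher numbers for weaker inhibition), compound 1 gives "not active" (no number reported).
Compound 2 `CCOC(=O)c1oc2c(C#N)c(OC)cc(OC)c2c1C`: in this assay compound 2 gives "not active" (no number reported).
Compound 3 `CCCNC(=O)c1oc2c(C(N)=O)c(OC)cc(OC)c2c1C`: in this assay compound 3 gives > 93600 nM, which is a limit of the assay and not a number.

Among the three values shown, compound 3 is the only one that comes with any figure at all, and that figure is a limit: the limit of > 93600 nM in this assay, at which 1 of the 3 values shown sits. The two other compounds carry no number. So compound 3 stands at the edge of what this assay can report, with nothing stronger or weaker to compare it against.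

Compound 4 `COc1cc(OC)c2c(C)c(C(N)=O)oc2c1C(N)=O` differs from compound 3 in a single place: hydrogen in place of propyl on an amide-type nitrogen. Within the data shown here, no measured pair of compounds shares this kind of change, so no step size can be read off. Given that compound 3 sits at a limit, no step beyond the scatter is expected in this assay, and compound 4 is expected to give 100000 nM, within 40000 nM to 300000 nM, a change of a step that the limit leaves unreadable from compound 3 to compound 4 that is expected to be none beyond the scatter.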

Compound 4, half-maximal inhibitory concentration: 22600 nM
Compound 4: the middle estimate sits 4.4-fold (0.65 log units) above what was measured; the whole stated range lies above it.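

In this assay the change from propylcarbamoyl to carbamoyl gives an at least 4.1-fold lower number from compound 3 to compound 4 (0.61 log units; beyond the scatter), the first sign among these compounds that this position can move the read-out at all. Compound 4 gives 22600 nM, the only real number among the compounds shown, and it gives this series a measured point to compare against. The true size of the step stays unknown, since compound 3 sits at a limit and not at a number: the limit of > 93600 nM in this assay, at which 1 of the 4 values shown sits.

Whether the number falls gradually as the chain on that nitrogen shortens remains open, as a methyl or an ethyl group there is not among the compounds shown. Also open, as far as these compounds go, is how a carboxylic acid in place of the carbamoyl group would read in this assay.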